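Removing one methoxy from the ring on the carbonyl

The source may report more compounds than this note shows. Statements on the series, on what has been measured and on what is new or still open speak of the compounds shown alone.

In a functional assay on KM12 cells (Homo sapiens) for inhibition, read by sulforhodamine B assay, with a stated time of 48 h (on this read-out higher numbers stand for weaker inhibition of growth and lower numbers for stronger inhibition of growth), the measured compounds are:
compound 1, `COc1cc(-c2cc(/C=C/C(=O)c3ccc(N)cc3)[nH]n2)cc(OC)c1OC`, at 1410 nM
compound 2, `COc1cc(-c2cc(/C=C/C(=O)c3ccc(Cl)c(Cl)c3)[nH]n2)cc(OC)c1OC`, at 3370 nM
compound 3, `COc1ccc(C(=O)/C=C/c2cc(-c3cc(OC)c(OC)c(OC)c3)n[nH]2)cc1OC`, at 1070 nM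

Compound 3 holds the lowest number of the three; toward compound 1 the gap lies within the scatter, toward compound 2 it lies beyond it. Compound 4, `COc1ccc(C(=O)/C=C/c2cc(-c3cc(OC)c(OC)c(OC)c3)n[nH]2)cc1`, differs from compound 3 by hydrogen in place of methoxy on an aromatic carbon. Among the compounds with values here, no measured step removes a single methoxy; the steps that touch this ring swap it whole: a 1.3-fold lower number from compound 1 to compound 3 (0.12 log units; within the scatter) and a 3.1-fold lower number from compound 2 to compound 3 (0.50 log units; beyond the scatter). Both are modest, so the removal is expected to shift this assay little. Compound 4 is therefore estimated at 1500 nM, within 600 nM to 3500 nM. That estimate corresponds to an expected step of a 1.4-fold higher number from compound 3 to compound 4 (0.15 log units; within the scatter).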

Compound 4, concentration for 50% growth inhibition: 1560 nM
The estimate for compound 4 lay 1.0-fold (0.02 log units) below the measured number, within the range that was stated.
By their numbers in this assay, from the lowest: compounds 3, 1 and 4 (each within the scatter of the next); then compound 2.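

In this assay, taking away the methoxy ortho to a methoxy group leaves the number within the scatter (a 1.5-fold higher number from compound 3 to compound 4 (0.16 log units; within the scatter)), so here the 4-methoxyphenyl group serves about as well as the 3,4-dimethoxyphenyl group. Methoxy in place of amino also stays within the scatter (a 1.1-fold higher number from compound 1 to compound 4 (0.04 log units; within the scatter)), while 4-methoxyphenyl in place of 3,4-dichlorophenyl gives a modest step beyond it (a 2.2-fold lower number from compound 2 to compound 4 (0.33 log units; beyond the scatter)). Nothing measured here bears on why these steps have these sizes. The compounds shown leave open what a hydroxy group or an ethoxy group would do at this place on the ring.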